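The compounds below may be only part of what the source reports. "The series", "measured", "known", "first", "only" and "open" are said of these compounds alone.

Compound 1 `COc1cc2c(Oc3ccc(NC(=O)c4nn(-c5ccccc5F)c(=O)c5ccccc45)cc3F)ccnc2cc1OCCCN1CCN(C)CC1` and compound 2 `COc1cc2c(Oc3ccc(NC(=O)c4nn(-c5ccc(Br)cc5)c(=O)c5ccccc45)cc3F)ccnc2cc1OCCCN1CCN(C)CC1` share one core and differ in a single place: 4-bromophenyl in place of 2-fluorophenyl on an aromatic nitrogen. In a functional assay on NCI-H460 cells (Homo sapiens) for cytotoxicity, read by MTT assay, with a stated time of 72 h (a higher number here means a weaker inhibitor, a lower number a stronger inhibitor), compound 1 gives 230 nM, while compound 2 gives 250 nM, so that a 1.1-fold higher number from compound 1 to compound 2 (0.04 log units; within the scatter). Compound 3 `COc1cc2c(Oc3ccc(NC(=O)c4nn(-c5ccccc5F)c(=O)c5ccccc45)cc3F)ccnc2cc1OCCCN1CCC(C)CC1` differs from compound 1 elsewhere, by 4-methylpiperidin-1-yl in place of 4-methylpiperazin-1-yl on a saturated chain carbon, three bonds along the chain from an oxygen on an aromatic ring; in this assay compound 3 gives 200 nM, and a 1.2-fold lower number from compound 1 to compound 3 (0.06 log units; within the scatter). Compound 4 `COc1cc2c(Oc3ccc(NC(=O)c4nn(-c5ccc(Br)cc5)c(=O)c5ccccc45)cc3F)ccnc2cc1OCCCN1CCC(C)CC1` carries the core of compound 3 and repeats the same change already seen between compound 1 and compound 2: 4-bromophenyl in place of 2-fluorophenyl on an aromatic nitrogen. The expectation for compound 4 rests on that earlier step, a 1.1-fold higher number from compound 1 to compound 2 (0.04 log units; within the scatter), which stayed within the scatter. The expected step here is therefore a 1.1-fold higher number from compound 3 to compound 4 (0.04 log units; within the scatter). Compound 4 is estimated to give 220 nM in this assay, with a likely range from 110 nM to 450 nM.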

Compound 4, half-maximal inhibitory concentration: 350 nM
The estimate for compound 4 lay 1.6-fold (0.20 log units) below the measured number, and the stated range covers the measured number.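

In this assay, 4-bromophenyl in place of 2-fluorophenyl on the aromatic nitrogen gives a 1.8-fold higher number from compound 3 to compound 4 (0.24 log units; within the scatter), and this step agrees with the one seen earlier on the other core: the same change on two cores in this assay, a 1.1-fold higher number (0.04 log units; within the scatter) from compound 1 to compound 2 and a 1.8-fold higher number (0.24 log units; within the scatter) from compound 3 to compound 4, 1.6-fold (0.21 log units) apart, within the scatter of two such steps. Likewise, 4-methylpiperidin-1-yl in place of 4-methylpiperazin-1-yl gives a 1.4-fold higher number from compound 2 to compound 4 (0.15 log units; within the scatter), which also agrees with its earlier step: the same change on two cores in this assay, a 1.2-fold lower number (0.06 log units; within the scatter) from compound 1 to compound 3 and a 1.4-fold higher number (0.15 log units; within the scatter) from compound 2 to compound 4, 1.6-fold (0.21 log units) apart, within the scatter of two such steps. Each change therefore carries between these two cores without a step beyond the scatter, but this does not show that either change truly shifts the number, or that the agreement would hold on other cores.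

The compounds shown leave open how a plain phenyl or a 4-methoxyphenyl would behave on the aromatic nitrogen. They also leave open what a morpholine would do at the end of the chain.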